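The source may report more compounds than this note shows. Statements on the series, on what has been measured and on what is new or still open speak of the compounds shown alone.

Working notes. For the measured compounds named here, in a functional assay on HeLa cells (Homo sapiens) for cytotoxicity, read by neutral red uptake, with a stated time of 3 days (a higher number here means a weaker inhibitor, a lower number a stronger inhibitor), compound 1 `[N-]=[N+]=Nc1c(F)c(N)c2c(=O)cc(-c3ccc(N)c(F)c3)oc2c1F` gives 1200 nM, and compound 2 `CCCCCC(=O)OCc1c(F)c(N)c2c(=O)cc(-c3ccc(N)c(F)c3)oc2c1F` gives 34000 nM, which stands as the higher of the two numbers; the single step recorded, a 28-fold higher number from compound 1 to compound 2 (1.45 log units; beyond the scatter), is large. Compound 3 `NCc1c(F)c(N)c2c(=O)cc(-c3ccc(N)c(F)c3)oc2c1F` differs from compound 2 by amino in place of (pentylcarbonyl)oxy on a saturated chain carbon bound to an aromatic carbon, so the ester portion leaves and a small polar group returns, a change that runs roughly counter to a 28-fold higher number from compound 1 to compound 2 (1.45 log units; beyond the scatter). A lower number is therefore expected for compound 3, estimated at 3000 nM within 800 nM to 12000 nM, a step of an 11-fold lower number from compound 2 to compound 3 (1.05 log units; beyond the scatter).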

Compound 3, half-maximal inhibitory concentration: 8800 nM
Estimate against measurement, compound 3: 2.9-fold (0.47 log units) below; the range from low to high includes it.
By their numbers in this assay, from the lowest: compound 1; then compound 3; then compound 2.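

In this assay, amino in place of (pentylcarbonyl)oxy on a saturated chain carbon bound to an aromatic carbon gives a 3.9-fold lower number from compound 2 to compound 3 (0.59 log units; beyond the scatter). This recovers only part of the earlier loss, and aminomethyl in place of azido on an aromatic carbon still leaves a 7.3-fold higher number from compound 1 to compound 3 (0.87 log units; beyond the scatter). Removing the ester chain therefore does not by itself restore the number of compound 1. Nothing available bears on the cause of these shifts.

Open, from the compounds shown here alone, is whether a hydroxymethyl group, a carboxylic acid or a shorter ester would read closer to azido at this place.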